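This account rests on a few compounds, and the source may have more. Where it says the series, first, only, none or still open, it means among the compounds named here.

Of the compounds shown here, three have been measured in an assay on CHO cells for displacement of a labelled ligand from 5-hydroxytryptamine receptor 7 (Homo sapiens); on this read-out higher numbers stand for weaker inhibition and lower numbers for stronger inhibition. Compound 1, `CCC1(CCCCN2CCN(c3ccc(Cl)cc3)CC2)C(=O)Nc2ccccc21`, gives 0.38 nM; 0.38 nM (2 entries). Compound 2, `CCC1(CCCCN2CCN(c3cccc(Cl)c3)CC2)C(=O)Nc2cc(F)ccc21`, gives 0.67 nM. Compound 3, `CC(C)CC1(CCCCN2CCN(c3cccc(Cl)c3)CC2)C(=O)Nc2ccccc21`, gives 1.8 nM, which is the highest of the two single numbers at hand; the nearest, compound 2, lies a good way lower, beyond the usual scatter, while compound 1 has two entries rather than one number.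

Compound 4, `CCC1(CCCCN2CCN(c3cccc(Cl)c3)CC2)C(=O)Nc2ccccc21`, has not yet been measured. Set against compound 3 the change is methyl in place of isopropyl on a saturated chain carbon bound to a saturated ring carbon. Compounds 1 and 2 both carry the ethyl group that this change produces, and both give lower numbers than compound 3. On that basis the step from compound 3 to compound 4 is expected to go downward, toward stronger inhibition, and to exceed the scatter, the expected size being a 3.0-fold lower number from compound 3 to compound 4 (0.48 log units; beyond the scatter). For compound 4 the estimate in this assay is 0.6 nM, with a range from 0.25 nM to 1.5 nM.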

Compound 4, inhibition constant: 0.41 nM
Compound 4: the middle estimate sits 1.5-fold (0.17 log units) above what was measured, and the stated range covers the measured number.
By their numbers in this assay, from the lowest: compounds 4 and 2 (each within the scatter of the next); then compound 3.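

In this assay, the one-place change from the isobutyl of compound 3 to the ethyl of compound 4 gives a 4.4-fold lower number from compound 3 to compound 4 (0.64 log units; beyond the scatter), so this saturated ring carbon's chain clearly matters, and the shorter of the two chains goes with stronger inhibition. Hydrogen in place of fluoro on an aromatic carbon gives a 1.6-fold lower number from compound 2 to compound 4 (0.21 log units; within the scatter), so this change cannot be told apart from repeat-measurement noise. Nothing at hand explains why either number moves as it does.

With only ethyl and isobutyl at this place, two chains cannot show how the number would respond to a straight butyl chain, or to a chain ending in an amine or a carboxylic acid. From the compounds shown here alone, whether fluoro would be as well tolerated on other aromatic carbons also remains open.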